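A few compounds are considered here, and "the series" means these few. Any claim that something is new, unique, unknown or untested is made for them only; others in the source may bear on it.

Working notes on the series. Compound 1 `C[C@]1(CN2CCc3nc(-c4ccc(F)cc4)oc3C2)Cn2cc([N+](=O)[O-])nc2O1` and compound 2 `C[C@]1(CN2CCc3nc(C4CC4)ccc3C2)Cn2cc([N+](=O)[O-])nc2O1` share the nitroimidazooxazine-bearing core with a bicyclic amine; compound 3 `C[C@]1(CN2CCc3nc(-c4ccc(F)c(Cl)c4)ccc3C2)Cn2cc([N+](=O)[O-])nc2O1` belongs to the same set but has not yet been tested. In an ADME assay on Vero cells (Chlorocebus sabaeus) for cytotoxicity, read by MTT assay, with a stated time of 72 h (a higher number here means that more compound is tolerated, a lower number that less compound is tolerated), compound 1 gives > 32 ug/mL, which is a limit of the assay and not a number. For compound 2 this assay gives "not determined" (no result reported), so compound 2 has no number of its own to stand on. Of the two results shown in this assay, the only one available is that of compound 1, as noted in the limit of > 32 ug/mL in this assay, at which 1 of the 2 values shown sits. Among the measured compounds shown here, no step between measured compounds can therefore be computed here.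

Compound 3 differs from compound 2 by 3-chloro-4-fluorophenyl in place of cyclopropyl on an aromatic carbon. For the measured compounds named here, with no measured step to draw on, the expectation for the move from compound 2 to compound 3 in this assay is a change no larger than the usual scatter, in no particular direction. Compound 3 is expected to give about 32 ug/mL in this assay, within a range from 12 ug/mL to 64 ug/mL.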

Compound 3, half-maximal cytotoxic concentration: > 32 ug/mL
Compound 3 gave a limit, no number; the forecaster's own chance of this, stated with the estimate: 65%; the middle value lies on the limit itself.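

In this assay compound 3 gives > 32 ug/mL, which is a limit of the assay and not a number. Among the compounds shown here, compound 2 has no result to set against it, so no step from compound 2 to compound 3 can be read. The compounds shown leave open whether 3-chloro-4-fluorophenyl in place of cyclopropyl changes how much compound is tolerated: the limit of > 32 ug/mL in this assay, at which 2 of the 3 values shown sit.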